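The source may report more compounds than this note shows. Statements on the series, on what has been measured and on what is new or still open speak of the compounds shown alone.

Measured in a functional assay on A549 cells (Homo sapiens) for cytotoxicity, read by sulforhodamine B assay, with a stated time of 72 h (a lower number here means a stronger inhibitor, a higher number a weaker inhibitor), so far:

- compound 1 `CCCC(=O)Nc1ccn([C@@H]2CO[C@H](CO)O2)c(=O)n1` gives 6600 nM
- compound 2 `CCCCCCC(=O)Nc1ccn([C@@H]2CO[C@H](CO)O2)c(=O)n1` gives 1040 nM
- compound 3 `CCCCCCCCCCCC(=O)Nc1ccn([C@@H]2CO[C@H](CO)O2)c(=O)n1` gives 15 nM

Compound 2 holds the second highest of the three numbers, with compound 1 above it and compound 3 below it. The next structure, compound 4 `CCCCCCCCCCCCCCCC(=O)Nc1ccn([C@@H]2CO[C@H](CO)O2)c(=O)n1`, carries nonyl in place of hydrogen on a saturated chain carbon, six bonds along the chain from a carbonyl carbon on the same chain. Among the compounds with values here, the closest precedent is the pentyl change at the same place, a 69-fold lower number from compound 2 to compound 3 (1.84 log units; beyond the scatter), and the nonyl change extends further along that chain. The propyl and octyl changes on compound 1 also bear on it, as a 6.3-fold lower number from compound 1 to compound 2 (0.80 log units; beyond the scatter) and a 440-fold lower number from compound 1 to compound 3 (2.64 log units; beyond the scatter). Among these compounds the number falls as the chain lengthens, and none goes against this. Nothing yet shows whether the fall continues beyond compound 3 , so a levelling off is allowed for. Expected here is an 87-fold lower number from compound 2 to compound 4 (1.94 log units; beyond the scatter), a large step to a lower number, similar in size to the pentyl step. The estimate for compound 4 is 12 nM, with an expected range from 1.5 nM to 120 nM in this assay.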

Compound 4, half-maximal inhibitory concentration: 4 nM
Compound 4: the middle estimate sits 3.0-fold (0.48 log units) above what was measured; the measured number falls inside the stated range.
By their numbers in this assay, from the lowest: compound 4; then compound 3; then compound 2; then compound 1.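

In this assay the fall in the number does not stop at compound 3: the nonyl change gives a 260-fold lower number from compound 2 to compound 4 (2.41 log units; beyond the scatter), and the butyl change still gives a 3.8-fold lower number from compound 3 to compound 4 (0.57 log units; beyond the scatter), so all four compounds now fall in order of chain length with none going against it. That last step is only modest, whereas the pentyl change gave a 69-fold lower number from compound 2 to compound 3 (1.84 log units; beyond the scatter), so the fall continues but in a smaller step at this end of the series. Nothing at hand gives a reason for this trend.

From the compounds shown here alone, whether a longer chain than that of compound 4 lowers the number further, holds it or raises it remains open. Also open, going by these compounds, is whether a chain carrying an amine or a carboxylic acid would follow the same order.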